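The compounds below may be only part of what the source reports. "The series", "measured", "known", "first", "only" and "open" are said of these compounds alone.

Among the compounds with values here, compound 3 `CC(=O)N(C)c1ccc(Sc2ncc([C@@]3(C)COC(C)(C)O3)s2)cc1` stands at the lowest number of the three compounds measured so far in a functional assay on blood for inhibition of Polyunsaturated fatty acid 5-lipoxygenase (Homo sapiens); on this read-out higher numbers stand for weaker inhibition and lower numbers for stronger inhibition: compound 3 gives 70 nM. Compound 1 `CC(=O)N(C)c1ccc(S(=O)(=O)c2cc(C3(C)COC(C)(C)O3)cs2)cc1` gives 840 nM in this assay, and compound 2 `CC(=O)N(C)c1ccc(Sc2ncc([C@]3(C)COC(C)(C)O3)s2)cc1` gives 6210 nM. Within the data shown here, the only step between two measured compounds that differ in one place is an 89-fold lower number from compound 2 to compound 3 (1.95 log units; beyond the scatter); that step rests on (the fact that compounds 2 and 3 differ only in the configuration as drawn), and it says nothing about the group on the six-membered ring.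

Compound 4 `C/C(=N\O)c1ccc(Sc2ncc([C@@]3(C)COC(C)(C)O3)s2)cc1` differs from compound 3 by a group of 4 heavy atoms (2 carbon, 1 nitrogen, 1 oxygen; no ring) in place of a group of 5 heavy atoms (3 carbon, 1 nitrogen, 1 oxygen; no ring), on an aromatic carbon; the entering group has no common name. Among the measured compounds shown here, none of the measured steps bears on this change, since the one measured step concerns only the configuration at the saturated ring carbon, and compound 1 differs from the others in more than one place. No measured evidence therefore points in either direction for the step from compound 3 to compound 4, and the expectation is a shift of no more than the scatter, a 1.3-fold higher number from compound 3 to compound 4 (0.11 log units; within the scatter), held with a wide range. For compound 4 the estimated value in this assay is 90 nM, expected to fall between 25 nM and 350 nM.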

Compound 4, half-maximal inhibitory concentration: 130 nM
Compound 4: the middle estimate sits 1.4-fold (0.16 log units) below what was measured, within the range that was stated.
By their numbers in this assay, from the lowest: compounds 3 and 4 (each within the scatter of the next); then compound 1; then compound 2.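

In this assay the aromatic carbon para to a large group takes a change of group with no reading beyond the scatter: the data give a 1.9-fold higher number from compound 3 to compound 4 (0.27 log units; within the scatter) and so do not separate the two groups at this position. Acetyl(methyl)amino, with 0 hydrogen-bond donors and 1 hydrogen-bond acceptor, is therefore not the only group compatible with a low number here, since the entering group, with 1 hydrogen-bond donor and 2 hydrogen-bond acceptors, stays within the scatter of it on the shared core. The one available line of explanation concerns only configuration and offers no reason for this result.

Open, as far as these compounds go, is how far this holds for groups of other kinds at the same aromatic carbon, such as a carboxylic acid, a primary amine, a longer alkyl chain or plain hydrogen. Also open, from the compounds shown here alone, is whether the same exchange would behave alike in the configuration drawn in compound 2 or on the core of compound 1.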